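Hydrazone aryl swap in a triazolylpyridine ether series

The compounds below may be only part of what the source reports. "The series", "measured", "known", "first", "only" and "open" are said of these compounds alone.

Among the measured compounds shown here, compound 1 `CN(C)CCn1cnnc1-c1cc(Oc2ccc(NC(=O)N/N=C/c3cccc(O)c3)cc2F)ccn1` carries the lowest of the two numbers so far: in a functional assay on HT-29 cells (Homo sapiens) for cytotoxicity, read by MTT assay, with a stated time of 72 h (on this read-out higher numbers stand for weaker inhibition and lower numbers for stronger inhibition), compound 1 gives 330 nM, while compound 2 `CN(C)CCn1cnnc1-c1cc(Oc2ccc(NC(=O)N/N=C/c3ccc(F)cc3Cl)cc2F)ccn1` gives 510 nM. For the measured compounds named here, the one measured step, a 1.5-fold higher number from compound 1 to compound 2 (0.19 log units; within the scatter), shows that exchanging the aryl group on the carbon with a double bond to nitrogen leaves the read-out essentially unchanged. Compound 3 `CN(C)CCn1cnnc1-c1cc(Oc2ccc(NC(=O)N/N=C/c3ccccc3O[N+](=O)[O-])cc2F)ccn1` differs from compound 1 by 2-(nitrooxy)phenyl in place of 3-hydroxyphenyl on a carbon with a double bond to nitrogen. Going by the values given here, only the step from compound 1 to compound 2 bears on this change, and it stayed within the scatter, so for compound 3 a step of a 1.4-fold higher number from compound 1 to compound 3 (0.13 log units; within the scatter) in this assay is expected, with no movement beyond the scatter. Compound 3 is estimated at 450 nM, within 150 nM to 1400 nM.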

Compound 3, half-maximal inhibitory concentration: 950 nM
Estimate against measurement, compound 3: 2.1-fold (0.32 log units) below, within the range that was stated.
By their numbers in this assay, from the lowest: compounds 1, 2 and 3 (each within the scatter of the next, the first and the last beyond it).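

Among the compounds shown here, at the carbon with a double bond to nitrogen, the aryl swap can now be told from the scatter in this assay: 2-(nitrooxy)phenyl in place of 3-hydroxyphenyl gives a 2.9-fold higher number from compound 1 to compound 3 (0.46 log units; beyond the scatter) and is the first change here to pass it. Against 2-chloro-4-fluorophenyl, the same group gives a 1.9-fold higher number from compound 2 to compound 3 (0.27 log units; within the scatter) and does not separate the two compounds. No measurement at hand accounts for the shift. Still open, from the compounds shown here alone, is whether the nitrooxy group or its ring position sets the shift, and how a 2-hydroxyphenyl or an unsubstituted phenyl would read here.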